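The source may hold more compounds than are shown below. What is called first, only, known or untested is meant among the compounds shown, and "the series" means these compounds.

Measured in a functional assay on A-375 cells (Homo sapiens) for cytotoxicity, read by CCK-8 assay, with a stated time of 24 h; a lower number here means a stronger inhibitor, a higher number a weaker inhibitor:
- compound 1 `COc1ccccc1Oc1c(N)nc(-c2cccc(C)c2)nc1Cl`: 65300 nM
- compound 2 `COc1ccccc1Oc1c(N)nc(-c2ccc(Cl)cc2)nc1Cl`: 1030 nM
- compound 3 `COc1ccccc1Oc1c(N)nc(-c2cccc(C)c2)nc1OCCO`: 1380 nM

Compound 3 stands well under compound 1, as shown by a 47-fold lower number from compound 1 to compound 3 (1.68 log units; beyond the scatter). That step is the exchange of chloro for 2-hydroxyethoxy. Compound 3 and compound 2 cannot be told apart, since their two values lie within the scatter of each other.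

The next compound is compound 4 `COc1ccccc1Oc1c(N)nc(-c2cccc(Br)c2)nc1OCCO`, which keeps the 2-hydroxyethoxy group and differs from compound 3 by bromo in place of methyl on an aromatic carbon. Among the measured compounds shown here, the closest evidence is a 63-fold lower number from compound 1 to compound 2 (1.80 log units; beyond the scatter), the only measured change on this aryl group. It is large, but it moves the substituent as well as exchanging it, and it was measured with chloro on the core. For the measured compounds named here, no measured pair changes the aryl group with 2-hydroxyethoxy in place, so whether that large step carries over is unknown. Compound 3 has already reached 1380 nM, so only a small move towards a lower number is expected, with nothing firmly expected beyond the scatter. The expected change is a 1.7-fold lower number from compound 3 to compound 4 (0.24 log units; within the scatter). For compound 4 the estimate is 800 nM, with an expected range of 200 nM to 3000 nM.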

Compound 4, half-maximal inhibitory concentration: 650 nM
Compound 4: middle estimate off by 1.2-fold (0.09 log units), on the high side; low and high end bracket the measured number.
By their numbers in this assay, from the lowest: compounds 4, 2 and 3 (each within the scatter of the next, the first and the last beyond it); then compound 1.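

In this assay, among the compounds shown here, the exchange of 3-methylphenyl for 3-bromophenyl gives a 2.1-fold lower number from compound 3 to compound 4 (0.33 log units; beyond the scatter) and is the first measured change on this aryl group with 2-hydroxyethoxy on the core and with the substituent kept in the same place on the ring. The step is modest and points the same way as a 63-fold lower number from compound 1 to compound 2 (1.80 log units; beyond the scatter) on the same aryl group, but that larger step also moved the substituent, exchanged methyl for chloro and was read with chloro on the core, so the two steps do not isolate the same change and the smaller size of the new one cannot be assigned to any single difference. No measured property or other independent result on hand accounts for the gain from bromo in place of methyl.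

The compounds shown leave open whether the same exchange gives a comparable step with chloro on the core, and whether 4-chlorophenyl keeps its value with 2-hydroxyethoxy in place. They also leave open how a nitrile or trifluoromethyl group on the aryl ring would read, and how an amine or a longer chain ending in hydroxy would read in place of 2-hydroxyethoxy.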